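This account rests on a few compounds, and the source may have more. Where it says the series, first, only, none or still open, it means among the compounds named here.

Working notes on the series. In an ADME assay on microsomes from liver (Homo sapiens) for metabolic stability, read by LC-MS, using NADPH, with stated times of 5 min and 30 min, tested at 1 uM (on this read-out lower numbers stand for a less stable compound and higher numbers for a more stable compound), compound 1 (`COc1cccc(S(=O)(=O)/C=C/c2ccc(Cl)cn2)c1`) gives 9.6% and compound 2 (`COc1ccccc1/C=C/S(=O)(=O)c1ccccn1`) gives 71%. Compound 2 therefore holds the higher of the two numbers, and the gap between them lies beyond the scatter. Among the compounds with values here, the series so far offers no measured step between compounds that differ in one place, so nothing measured shows how a single change acts on this read-out.

The next compound is compound 3 (`O=S(=O)(/C=C/c1ccccc1F)c1ccccn1`), which differs from compound 2 by fluoro in place of methoxy on an aromatic carbon. In words, this is fluoro in place of methoxy on an aromatic carbon, ortho to a large group. Within the data shown here, with no measured step to draw on, the expectation starts from compound 2 at 71% and favours no direction. The estimated change, a number 1 percentage points higher from compound 2 to compound 3 (within the scatter), is expected to stay within the scatter. Among the measured compounds shown here, the range is kept wide, since the only two numbers available lie far apart. The estimate in this assay for compound 3 is 72%, with an expected range from 48% to 90%.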

Compound 3, percent of the compound remaining: 91%
Beside the measured number, compound 3's estimate is 19 percentage points below it, and the stated range ends below it.
By their numbers in this assay, from the lowest: compound 1; then compound 2; then compound 3.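

In this assay, the series now has its first measured single change: fluoro in place of methoxy on an aromatic carbon, ortho to a large group, gives a number 20 percentage points higher from compound 2 to compound 3 (beyond the scatter). Within the data shown here, this shows that the read-out responds to what sits at this place on the six-membered aromatic ring of carbon only, and that exchanging methoxy, with 2 heavy atoms, for fluoro, with 1 heavy atom, moves the number upward beyond the scatter, which the earlier compounds, with no step between them, could not show. Nothing at hand bears on the reason for this step, so it stands as an observation only.

As far as these compounds go, with a single replacement at this place, it remains open whether the rise goes with the departure of methoxy or the arrival of fluoro, and a plain hydrogen, chloro or methyl at the same carbon would help separate the two. Also open, from the compounds shown here alone, is whether the same exchange acts in the same direction on another core, such as the core of compound 1, as one step establishes no pattern.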